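This account rests on a few compounds, and the source may have more. Where it says the series, first, only, none or still open, it means among the compounds named here.

Notes on the series

Compound 1, `CC(C)(C)NC(=O)c1c(N)sc(-c2ccc(Cl)cc2)c1-c1ccc(Cl)cc1`, carries a tert-butyl group on the amide-type nitrogen. In a functional assay on PC-3 cells (Homo sapiens) for inhibition, read by sulforhodamine B assay, with a stated time of 72 h (on this read-out higher numbers stand for weaker inhibition and lower numbers for stronger inhibition), compound 1 gives 15100 nM, the highest of the three numbers recorded so far, and its steps to both other compounds lie beyond the scatter, so it is the weakest inhibitor of the set. Compound 2, `Nc1sc(-c2ccc(Cl)cc2)c(-c2ccc(Cl)cc2)c1C(=O)NC1CCCCC1`, gives 7300 nM in this assay, and compound 3, `Nc1sc(-c2ccc(Cl)cc2)c(-c2ccc(Cl)cc2)c1C(=O)NC1CC1`, gives 3680 nM. The two steps that bear on the present question both exchange tert-butyl for a carbocycle on the same nitrogen: a 2.1-fold lower number from compound 1 to compound 2 (0.32 log units; beyond the scatter) and a 4.1-fold lower number from compound 1 to compound 3 (0.61 log units; beyond the scatter). Between the two carbocycles the difference is small: a 2.0-fold lower number from compound 2 to compound 3 (0.30 log units; within the scatter).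

Compound 4, `Nc1sc(-c2ccc(Cl)cc2)c(-c2ccc(Cl)cc2)c1C(=O)NC1CCC1`, differs from compound 1 in one place: cyclobutyl in place of tert-butyl on an amide-type nitrogen. Cyclobutyl is a carbocycle of the same heavy-atom count as the groups it stands between in ring size, so the step from compound 1 to compound 4 is expected to resemble the steps to compound 2 and compound 3, with a modest move to a lower number and no basis for expecting anything beyond that range. Compound 4 is therefore estimated to give 5200 nM in this assay, with a likely range of 2600 nM to 10500 nM. The expected step is a 2.9-fold lower number from compound 1 to compound 4 (0.46 log units; beyond the scatter).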

Compound 4, half-maximal inhibitory concentration: 24800 nM
The estimate for compound 4 lay 4.8-fold (0.68 log units) below the measured number; measured number outside the range, above it.
By their numbers in this assay, from the lowest: compounds 3 and 2 (each within the scatter of the next); then compounds 1 and 4 (each within the scatter of the next).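

In this assay, a carbocycle on the amide-type nitrogen does not by itself lower the number: a 1.6-fold higher number from compound 1 to compound 4 (0.22 log units; within the scatter) leaves cyclobutyl level with tert-butyl, although the two groups have the same heavy-atom count and only cyclobutyl has a ring. Cyclobutyl also parts from the other two carbocycles, with a 6.7-fold higher number from compound 3 to compound 4 (0.83 log units; beyond the scatter) and a 3.4-fold higher number from compound 2 to compound 4 (0.53 log units; beyond the scatter), so the numbers do not follow ring size in a steady direction: the four-membered ring stands apart from both the smaller cyclopropyl and the larger cyclohexyl, which are themselves within the scatter of each other. No measurement available here accounts for this break in the ring series.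

The compounds shown leave open whether cyclopentyl would fall with compound 4 or with compound 2 and compound 3, and so whether compound 4 is a lone exception among the carbocycles. They also leave open how an open n-butyl chain, or a cyclobutyl ring carrying an amine or a hydroxyl group, would read at this nitrogen.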